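Saturated rings in place of aryl at the imidazole carbon

The compounds below may be only part of what the source reports. "The series", "measured", "known", "first", "only" and "open" are said of these compounds alone.

Measured so far:
compound 1 `CCCn1c(=O)c2nc(-c3ccccc3)[nH]c2n(C)c1=O` — 6.96 nM
compound 2 `CCCn1c(=O)n(C)c(=O)c2[nH]c(-c3cccs3)nc21` — 8.93 nM
compound 3 `CCCn1c(=O)n(C)c(=O)c2[nH]c(C3CCCC3)nc21` — 0.85 nM

Three compounds sharing one core differ only in the group on the aromatic carbon between two ring nitrogen atoms. In an assay on Cortex for displacement of a labelled ligand from adenosine receptor A1 (Rattus norvegicus) (a higher number here means a weaker inhibitor, a lower number a stronger inhibitor), compound 1 gives 6.96 nM; compound 2 gives 8.93 nM, within the scatter of compound 1. Compound 3 stands apart: an 11-fold lower number from compound 2 to compound 3 (1.02 log units; beyond the scatter), a saturated ring in place of an aromatic one.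

Compound 4 `CCCn1c(=O)c2nc(C3CCCCC3)[nH]c2n(C)c1=O` is not yet measured. The change from compound 1 is cyclohexyl in place of phenyl on an aromatic carbon. Going by the values given here, the one step that bears on it, from compound 2 to compound 3, was large and in the lowering direction, so a step of similar kind in this assay is expected: a 7.0-fold lower number from compound 1 to compound 4 (0.84 log units; beyond the scatter). Compound 4 is therefore estimated at 1 nM, with a range of 0.4 nM to 3 nM.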

Compound 4, inhibition constant: 5.02 nM
Estimate against measurement, compound 4: 5.0-fold (0.70 log units) below, outside the stated range (above it).
By their numbers in this assay, from the lowest: compound 3; then compounds 4, 1 and 2 (each within the scatter of the next).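

In this assay, cyclohexyl in place of phenyl gives a 1.4-fold lower number from compound 1 to compound 4 (0.14 log units; within the scatter) and so leaves the number within the scatter. A saturated ring entering on this aromatic carbon therefore does not by itself carry the effect seen in an 11-fold lower number from compound 2 to compound 3 (1.02 log units; beyond the scatter) and the outcome depends on the particular pair of groups. Nothing available here explains why the two steps part.

From the compounds shown here alone, whether the earlier step reflects cyclopentyl itself or the thiophen-2-yl it replaced remains open. So does the outcome of an amine or a carboxylic acid on the saturated ring at this position.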